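A few compounds are considered here, and "the series" means these few. Any claim that something is new, unique, unknown or untested is made for them only; others in the source may bear on it.

For the measured compounds named here, in a functional assay on A549 cells (Homo sapiens) for cytotoxicity, read by MTT assay, with a stated time of 72 h (a lower number here means a stronger inhibitor, a higher number a weaker inhibitor), compound 2 (`CNC(=O)c1cc(Oc2ccc(C(=O)/C=C/c3ccccc3)cc2)ccn1`) gives 5040 nM, the only actual number so far. Compound 1 (`CNC(=O)c1cc(Oc2ccc(C(=O)/C=C/c3ccc(Br)cc3)cc2)ccn1`) reads > 50000 nM, and this value is a limit of the assay, not a number. The next case is compound 3 (`CNC(=O)c1cc(Oc2ccc(C(=O)/C=C/c3ccc(OC)cc3)cc2)ccn1`), where the change is methoxy in place of hydrogen on an aromatic carbon, para to a large group.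

Going by the values given here, only one measured step bears on this change, and it concerns the same aromatic carbon: an at least 9.9-fold lower number from compound 1 to compound 2 (0.99 log units; beyond the scatter), with hydrogen in place of bromo. That is a single step, it has only a lower bound on its size, and it involves bromo rather than methoxy, so it offers more guidance on direction than on size. On the strength of an at least 9.9-fold lower number from compound 1 to compound 2 (0.99 log units; beyond the scatter), a move to a higher number is expected for the methoxy compound, probably a smaller move than that step, and a result close to compound 2 remains possible. The estimated change is a 2.8-fold higher number from compound 2 to compound 3 (0.44 log units; beyond the scatter). In this assay the expected value for compound 3 is 14000 nM, with an estimated range of 4000 nM to 45000 nM.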

Compound 3, half-maximal inhibitory concentration: > 50000 nM
Compound 3 gave a limit, no number; the forecaster's own chance of this, stated with the estimate: 20%; at least 3.5-fold (0.55 log units) between middle value and limit.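

In this assay, the change from phenyl to 4-methoxyphenyl gives an at least 9.9-fold higher number from compound 2 to compound 3 (0.99 log units; beyond the scatter). Methoxy therefore joins bromo: both substituents on this aromatic carbon, para to a large group, go with a higher number than hydrogen, and the earlier direction no longer rests on bromo alone. Compound 3 reads > 50000 nM, which is a limit of the assay and not a number. The step between compound 1 and compound 3 cannot be read, so bromo and methoxy cannot be ordered, and hydrogen remains the only group at this carbon with an actual number: the limit of > 50000 nM in this assay, at which 2 of the 3 values shown sit.

From the compounds shown here alone, whether fluoro, hydroxy or an amine on this carbon would give a number or another limit in this assay remains open. The compounds shown also leave open whether methoxy or bromo on another carbon of the same ring would go with the same move, since every substituent shown sits at this one place.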